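Swapping cyclopropyl for ethyl on the amine nitrogen

The source may report more compounds than this note shows. Statements on the series, on what has been measured and on what is new or still open speak of the compounds shown alone.

compound 1 `CC1(C)c2[nH]nc(NC(=O)c3ccc(F)cc3)c2CN1C(=O)C1CCN(C2CC2)CC1` gives 380 nM
compound 2 `CC(C)CC(=O)Nc1n[nH]c2c1CN(C(=O)C1CCN(C3CC3)CC1)C2(C)C` gives 320 nM

In a functional assay on A2780 cells (Homo sapiens) for antiproliferative activity, read by fluorescence, with a stated time of 72 h (on this read-out higher numbers stand for weaker inhibition and lower numbers for stronger inhibition), compound 1 gives 380 nM and has a single measured neighbour. That neighbour differs in the group on a carbonyl carbon, and the step is small (a 1.2-fold lower number from compound 1 to compound 2 (0.07 log units; within the scatter)), so the two numbers cannot be told apart.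

Compound 3 `CCN1CCC(C(=O)N2Cc3c(NC(=O)c4ccc(F)cc4)n[nH]c3C2(C)C)CC1` differs from compound 1 elsewhere, with ethyl in place of cyclopropyl on an amine nitrogen in a ring, counted as ethyl in place of cyclopropyl on an amine nitrogen in a ring and nothing more. Going by the values given here, no measured pair tests this nitrogen, and the one measured step (a 1.2-fold lower number from compound 1 to compound 2 (0.07 log units; within the scatter)) sits at another place, so it offers only a loose guide. No shift beyond the scatter is therefore expected in this assay and no direction can be argued. The expected size is a 1.1-fold lower number from compound 1 to compound 3 (0.04 log units; within the scatter) and that is only an estimate. Compound 3 is estimated at 350 nM with an expected range from 140 nM to 900 nM for now.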

Compound 3, half-maximal inhibitory concentration: 290 nM
Compound 3: the middle estimate sits 1.2-fold (0.08 log units) above what was measured; the range from low to high includes it.
By their numbers in this assay, from the lowest: compounds 3, 2 and 1 (each within the scatter of the next).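

Going by these compounds alone, the first measured change at the amine nitrogen in the ring shows that, in this assay, ethyl can stand in place of cyclopropyl with no shift that can be told from the scatter: a 1.3-fold lower number from compound 1 to compound 3 (0.12 log units; within the scatter). Removing the three-membered ring and going from 3 heavy atoms to 2 therefore gives no readable difference in this pair, which carries 4-fluorophenyl on the carbonyl carbon. No measurement at hand offers an explanation for this result.

Ethyl and cyclopropyl both contain carbon only, so it remains open how this nitrogen would respond to a benzyl group, a longer chain or a chain ending in a carboxylic acid. Going by these compounds, it also remains open whether the same swap would read alike with isobutyl on the carbonyl carbon, as in compound 2.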